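A few compounds are considered here, and "the series" means these few. Any claim that something is new, unique, unknown or untested is made for them only; others in the source may bear on it.

Measured compounds:
compound 1, `CC(CCNC(=O)c1c(Cl)cncc1Cl)N1CCC(C(Oc2cccc(C(=O)O)n2)c2ccc(C(F)(F)F)cc2)CC1`, in an ADME assay on PBMC cells (Homo sapiens) for cytotoxicity (a higher number here means that more compound is tolerated, a lower number that less compound is tolerated), gives 28700 nM
compound 2, `CCO/N=C(/c1ccc(Br)cc1)C1CCN(C(C)CCNC(=O)c2c(C)cc[n+]([O-])c2C)CC1`, in this assay gives > 177000 nM, which is a limit of the assay and not a number

Compound 1 holds the only number shown in this assay; the other entry is a limit. Compound 2 sits at the limit of > 177000 nM in this assay, at which 1 of the 2 values shown sits. Nothing more can be said of how the two compare beyond what these two values show.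

Compound 3, `COC(=O)c1cccc(OC(c2ccc(C(F)(F)F)cc2)C2CCN(C(C)CCNC(=O)c3c(Cl)cncc3Cl)CC2)n1`, has not yet been measured in this assay. It differs from compound 1 by methyl in place of hydrogen on an oxygen next to a carbonyl group. No step between measured compounds is shown, so the size of this change in this assay can only be guessed. The expectation is a modest move toward less tolerated compound, roughly at the edge of the usual scatter, in a 1.9-fold lower number from compound 1 to compound 3 (0.28 log units; within the scatter). For compound 3 the estimated value in this assay is 15000 nM, with a range from 5000 nM to 45000 nM.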

Compound 3, half-maximal cytotoxic concentration: 14600 nM
Compound 3: the middle estimate sits 1.0-fold (0.01 log units) above what was measured; the measured number falls inside the stated range.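

Among the compounds shown here, the first comparison in this assay between two compounds that differ in one place only is methyl in place of hydrogen on an oxygen next to a carbonyl group, read as carboxy to methoxycarbonyl, and it comes to a 2.0-fold lower number from compound 1 to compound 3 (0.29 log units; within the scatter). Within this single pair, the 6-carboxypyridin-2-yl and 6-(methoxycarbonyl)pyridin-2-yl groups cannot be told apart by this measurement, so the hydrogen on that oxygen is not shown to matter for the number obtained here on this core. Nothing among the data shown speaks to why the two compounds stand so close.

The compounds shown leave open whether other groups at this place, such as ethoxycarbonyl, a primary amide or a nitrile, would also stay within the scatter of compound 1. For the compounds shown here, they also leave open whether the same step from carboxy to methoxycarbonyl would read alike on a different core, or with the dichloro-substituted amide part replaced by another one, since only this one pair can be read.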